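Chain end swap: vinyl to methoxy

A few compounds are considered here, and "the series" means these few. Any claim that something is new, unique, unknown or untested is made for them only; others in the source may bear on it.

In a functional assay on MDA-MB-231 cells (Homo sapiens) for antiproliferative activity (a lower number here means a stronger inhibitor, a higher number a weaker inhibitor), compound 2 `C=CCCn1cc(-c2nc(Nc3ccc(NC(=O)CCCCCCC(=O)NO)cc3)nc3[nH]ccc23)cn1` gives 7400 nM and compound 1 `CCCn1cc(-c2nc(Nc3ccc(NC(=O)CCCCCCC(=O)NO)cc3)nc3[nH]ccc23)cn1` gives 9100 nM, so the two cannot be told apart. Compound 3 `COCCn1cc(-c2nc(Nc3ccc(NC(=O)CCCCCCC(=O)NO)cc3)nc3[nH]ccc23)cn1` carries methoxy in place of vinyl on a saturated chain carbon, two bonds along the chain from an aromatic nitrogen. Going by the values given here, the one measured step at this place, a 1.2-fold lower number from compound 1 to compound 2 (0.09 log units; within the scatter), stays within the scatter, though no measured compound carries methoxy here. The expected change is no shift beyond the scatter in either direction, an estimated 1.1-fold higher number from compound 2 to compound 3 (0.03 log units; within the scatter). The estimate for compound 3 is 8000 nM, with an expected range of 4000 nM to 16000 nM.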

Compound 3, half-maximal inhibitory concentration: 13300 nM
Beside the measured number, compound 3's estimate is 1.7-fold (0.22 log units) below it; the measured number falls inside the stated range.
By their numbers in this assay, from the lowest: compounds 2, 1 and 3 (each within the scatter of the next).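

In this assay, the place now holds methoxy as well as vinyl and methyl, and both new steps stay within the scatter (a 1.8-fold higher number from compound 2 to compound 3 (0.25 log units; within the scatter)) and (a 1.5-fold higher number from compound 1 to compound 3 (0.16 log units; within the scatter)). On this saturated chain carbon, two bonds along the chain from an aromatic nitrogen, exchanging either carbon end for methoxy, with its one hydrogen-bond acceptor, gives no step beyond the scatter. No available evidence bears on these small steps. As far as these compounds go, whether an amine, a carboxylic acid or a longer chain at this chain end would give a step beyond the scatter stays open.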